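Swapping Ethyl for Cyclohexyl: An Untested Growth Inhibitor

A few compounds are considered here, and "the series" means these few. Any claim that something is new, unique, unknown or untested is made for them only; others in the source may bear on it.

Of the compounds shown here, three sharing one core have been tested in a functional assay on NPC-TW01 cells (Homo sapiens) for inhibition, read by MTT assay, with a stated time of 72 h; a higher number here means a weaker inhibitor of growth, a lower number a stronger inhibitor of growth. Compound 1 `COC(=O)c1nc(C)n(-c2cccc(Br)c2)n1` gives only a limit of the test, > 100000 nM. Compound 2 `COC(=O)c1nc(C)n(-c2ccc(C(F)(F)F)cc2)n1` likewise stops at a limit, > 100000 nM. Going by the values given here, compound 3 `CCc1nc(C(=O)OC)nn1-c1ccc(F)cc1` is the one compound with a real number, giving 15800 nM in this assay. The remaining two values sit at the limit of > 100000 nM in this assay, at which 2 of the 3 values shown sit. Compound 4 `COC(=O)c1nc(C2CCCCC2)n(-c2ccc(F)cc2)n1` differs from compound 3 by a single change, (cyclohexyl in place of ethyl on an aromatic carbon), cyclohexyl in place of ethyl on an aromatic carbon. Among the compounds with values here, no measured pair of compounds shows what such a change does here. The step of a 2.0-fold lower number from compound 3 to compound 4 (0.30 log units; within the scatter) is expected to be small, perhaps a modest gain in potency, close to the usual scatter. Compound 4 is therefore estimated at 8000 nM, within a range from 2000 nM to 40000 nM.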

Compound 4, concentration for 50% growth inhibition: 30500 nM
Compound 4: middle estimate off by 3.8-fold (0.58 log units), on the low side, within the range that was stated.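

At this position, on an aromatic carbon between two ring nitrogen atoms, the change now has a measured size: in this assay, cyclohexyl in place of ethyl gives a 1.9-fold higher number from compound 3 to compound 4 (0.29 log units; within the scatter). A carbon-only group of 6 heavy atoms with one six-membered non-aromatic ring therefore reads the same, within the scatter, as a chain of 2 heavy atoms. Nothing available explains why these two groups read alike.

From the compounds shown here alone, whether an amine, a carboxylic acid or a longer chain at this same position would separate from ethyl stays open. So does whether cyclohexyl would behave the same way with a different group on the shared core.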